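A Pentyl Tail in Place of Phenyl on the Ketone Chain

The source may hold more compounds than are shown below. What is called first, only, known or untested is meant among the compounds shown, and "the series" means these compounds.

Of the compounds shown here, three have been measured in an assay on HEK-293T cells for inhibition of diacylglycerol lipase-alpha (Homo sapiens), read by colorimetric assay; a lower number here means a stronger inhibitor, a higher number a weaker inhibitor. Compound 1 `O=C(CCCCCc1ccccc1)c1nc2cccc(Br)c2o1` returns only the limit of the assay, > 10000 nM. Compound 2 `O=C(CCCCCCc1ccccc1)c1nnc(-c2ccco2)s1` likewise returns only the limit, > 10000 nM. For the measured compounds named here, compound 3 `O=C(CCCCc1ccccc1)c1nc2ncccc2o1` is the one compound with an actual number, giving 204 nM in this assay. It therefore stands alone among the measured values, the other two sitting at the limit (the limit of > 10000 nM in this assay, at which 2 of the 3 values shown sit). Going by the values given here, no pair of measured compounds differs in a single place, so nothing measured shows how any one change shifts the read-out.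

Compound 4 `CCCCCCCCCC(=O)c1nc2ncccc2o1` has not yet been measured. It differs from compound 3 by pentyl in place of phenyl on a saturated chain carbon, four bonds along the chain from a carbonyl carbon, with the shared core of compound 3 kept. Among the compounds with values here, with no measured step to anchor it, the step expected here, a 2.0-fold higher number from compound 3 to compound 4 (0.29 log units; within the scatter), is judged small, at most a modest weakening and possibly nothing beyond the usual scatter. Compound 4 is therefore estimated at 400 nM in this assay, with a range from 100 nM to 2000 nM.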

Compound 4, half-maximal inhibitory concentration: 74.1 nM
Compound 4: the middle estimate sits 5.4-fold (0.73 log units) above what was measured; the measured number lies below the stated range.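

In this assay, for the compounds shown here, pentyl in place of phenyl on a saturated chain carbon, four bonds along the chain from a carbonyl carbon, gives a 2.8-fold lower number from compound 3 to compound 4 (0.44 log units; beyond the scatter) and so supplies the first measured step in this set. It shows that, with the shared core kept, the six-membered aromatic ring is not required at this place on the chain, and that a tail with no ring gives the stronger inhibitor of this pair by a margin beyond the scatter. Cut one bond further out, the same difference reads benzyl to hexyl, but nothing measured here accounts for the direction or size of the step.

A single pair cannot show whether this result is particular to pentyl, or how it would change with a shorter propyl tail, a longer alkyl chain, a branched isobutyl tail, or an amine or a carboxylic acid at the chain end. The compounds shown also leave open whether pentyl in place of phenyl would give a step of similar direction and size on any core other than the one shared by compound 3 and compound 4.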